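A 4-bromophenyl group replaces the substituted ring of compound 3

A few compounds are considered here, and "the series" means these few. Any claim that something is new, unique, unknown or untested is made for them only; others in the source may bear on it.

In a functional assay on DU-145 cells (Homo sapiens) for inhibition, read by trypan blue exclusion, with a stated time of 96 h (on this read-out higher numbers stand for weaker inhibition of growth and lower numbers for stronger inhibition of growth), compound 3 `COc1ccc(/C=C(/SCc2ccc(F)cc2)C(=O)c2ccc(Br)cc2)cc1O` gives 1000 nM, level with compound 2 `O=C(/C(=C\c1ccc(Br)cc1)Sc1ccc(Br)cc1)c1ccc(Br)cc1` at 1000 nM. These two share the lowest number of the three, while compound 1 `Cc1cc(C)cc(/C=C(/SCc2ccc(F)cc2)C(=O)c2ccc(Br)cc2)c1` gives 10000 nM. Compound 4 `O=C(/C(=C\c1ccc(Br)cc1)SCc1ccc(F)cc1)c1ccc(Br)cc1` differs from compound 3 by 4-bromophenyl in place of 3-hydroxy-4-methoxyphenyl on a double-bonded chain carbon bound to a double-bonded chain carbon, with 4-bromophenyl in place of 3-hydroxy-4-methoxyphenyl. Going by the values given here, the only measured step at this place is a 10-fold lower number from compound 1 to compound 3 (1.00 log units; beyond the scatter), which is modest but beyond the scatter. Compound 2 also carries 4-bromophenyl there and gives 1000 nM, although it is not otherwise the same. A smaller change towards weaker inhibition is therefore expected, and the estimated step is a 2.0-fold higher number from compound 3 to compound 4 (0.30 log units; within the scatter). The estimate for compound 4 is 2000 nM, with an expected range of 400 nM to 10000 nM.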

Compound 4, concentration for 50% growth inhibition: 25000 nM
Compound 4: middle estimate off by 13-fold (1.10 log units), on the low side; measured number outside the range, above it.
By their numbers in this assay, from the lowest: compounds 2 and 3 (each within the scatter of the next); then compound 1; then compound 4.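

In this assay, 4-bromophenyl in place of 3-hydroxy-4-methoxyphenyl on a double-bonded chain carbon bound to a double-bonded chain carbon gives a 25-fold higher number from compound 3 to compound 4 (1.40 log units; beyond the scatter) and thus weakens inhibition, and a 2.5-fold higher number from compound 1 to compound 4 (0.40 log units; beyond the scatter) follows for the same group in place of 3,5-dimethylphenyl. With 4-bromophenyl held at that place, the sulfur group also counts: a 25-fold higher number from compound 2 to compound 4 (1.40 log units; beyond the scatter) follows from 4-fluorobenzyl in place of 4-bromophenyl on a sulfur. No measurement available here explains these steps. The compounds shown leave open whether the hydroxy or the methoxy of the 3-hydroxy-4-methoxyphenyl group carries the difference. On these data alone, how an amine or a carboxylic acid on that ring would read also remains open.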